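A few compounds are considered here, and "the series" means these few. Any claim that something is new, unique, unknown or untested is made for them only; others in the source may bear on it.

Compound 1 `Cc1cc(NS(=O)(=O)c2ccc(NC3=NC(=O)/C(=C\c4coc5ccccc5c4=O)S3)cc2)no1`: in a functional assay on MCF7 cells (Homo sapiens) for cytotoxicity, read by sulforhodamine B assay, with a stated time of 72 h (a higher number here means a weaker inhibitor, a lower number a stronger inhibitor), compound 1 gives > 100000 nM, which is a limit of the assay and not a number.
Compound 2 `Cc1cc(C)nc(NS(=O)(=O)c2ccc(NC3=NC(=O)/C(=C\c4coc5ccccc5c4=O)S3)cc2)n1`: in this assay compound 2 gives > 100000 nM, again a limit.
Compound 3 `O=C1/C(=C/c2coc3ccccc3c2=O)N=C(c2ccccc2)N1c1ccc(S(=O)(=O)Nc2ccccn2)cc1`: in this assay compound 3 gives > 100000 nM, again a limit.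

Compound 2 thus stands at the limit of the assay, and so do the other two compounds shown: the limit of > 100000 nM in this assay, at which 3 of the 3 values shown sit. Within the data shown here, the only step that joins two measured compounds, a step that the two limits leave unreadable from compound 1 to compound 2, cannot be read, as both of its ends are limits. The next compound, compound 4 `O=C1N=C(Nc2ccc(S(=O)(=O)Nc3nccs3)cc2)S/C1=C/c1coc2ccccc2c1=O`, differs from compound 2 in one place: 1,3-thiazol-2-yl in place of 4,6-dimethylpyrimidin-2-yl on a sulfonamide nitrogen. Among the measured compounds shown here, no measured step gives a readable size for a change of the group on the sulfonamide nitrogen; the one step of that kind is unreadable, and every compound shown sits at the limit. The step from compound 2 to compound 4 is therefore expected to be a number no higher from compound 2 to compound 4 (the limit leaves the size open), none beyond the scatter. Compound 4 is estimated at 100000 nM, most likely again only a limit, with a range from 20000 nM to 300000 nM.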

Compound 4, half-maximal inhibitory concentration: > 100000 nM
Compound 4 gave a limit, no number; the forecaster's own chance of this, stated with the estimate: 75%; the middle value lies on the limit itself.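

The steps to compound 4 from compound 1 and from compound 2 cannot be read, as both ends of each step are limits and not numbers: the limit of > 100000 nM in this assay, at which 4 of the 4 values shown sit.

The compounds shown leave open how strongly any of them acts on these cells, and whether changing the group on the sulfonamide nitrogen matters at all.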